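The source may report more compounds than this note shows. Statements on the series, on what has been measured and on what is new or still open speak of the compounds shown alone.

Compound 1 `COc1ccc(/C=C2\CCC/C(=C\c3cccc(Cl)c3)C2=O)cc1OC` gives 5100 nM in a functional assay on SW-620 cells (Homo sapiens) for cytotoxicity, read by MTT assay, with a stated time of 72 h; a higher number here means a weaker inhibitor, a lower number a stronger inhibitor. Compound 2 `COc1cccc(/C=C2\CCC/C(=C\c3ccc(OC)c(OC)c3)C2=O)c1` gives 3700 nM in this assay; the step of a 1.4-fold lower number from compound 1 to compound 2 (0.14 log units; within the scatter) corresponds to the change (methoxy in place of chloro on an aromatic carbon). Compound 3 `COc1ccc(/C=C2\CCC/C(=C\c3ccc(O)c(Cl)c3)C2=O)cc1OC` gives 7100 nM in this assay; its core differs from the core of compound 1 by hydroxy in place of hydrogen on an aromatic carbon. The steps of a 1.4-fold higher number from compound 1 to compound 3 (0.14 log units; within the scatter) and a 1.9-fold higher number from compound 2 to compound 3 (0.28 log units; within the scatter) both lie within the scatter, so no order among compounds 1, 2 and 3 is established. Compound 4 `COc1cc(/C=C2\CCC/C(=C\c3ccc(OC)c(OC)c3)C2=O)ccc1O` is not yet measured. It differs from compound 3 by methoxy in place of chloro on an aromatic carbon, the same kind of change as from compound 1 to compound 2, though here the place is ortho to a hydroxy group, so it is not the same change. Beside a 1.4-fold lower number from compound 1 to compound 2 (0.14 log units; within the scatter), the step expected is a 1.4-fold lower number from compound 3 to compound 4 (0.15 log units; within the scatter), resting on that single earlier step alone. Compound 4 is therefore expected near 5000 nM, estimated between 2500 nM and 10000 nM.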

Compound 4, half-maximal inhibitory concentration: 4500 nM
Estimate against measurement, compound 4: 1.1-fold (0.05 log units) above, and the stated range covers the measured number.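

In this assay the exchange of chloro for methoxy reads alike on the two cores: the same change on two cores in this assay, a 1.4-fold lower number (0.14 log units; within the scatter) from compound 1 to compound 2 and a 1.6-fold lower number (0.20 log units; within the scatter) from compound 3 to compound 4, 1.1-fold (0.06 log units) apart, within the scatter of two such steps. The exchange of hydrogen for hydroxy reads alike as well: the same change on two cores in this assay, a 1.4-fold higher number (0.14 log units; within the scatter) from compound 1 to compound 3 and a 1.2-fold higher number (0.09 log units; within the scatter) from compound 2 to compound 4, 1.1-fold (0.06 log units) apart, within the scatter of two such steps. Among the compounds shown here, the new steps, a 1.6-fold lower number from compound 3 to compound 4 (0.20 log units; within the scatter) and a 1.2-fold higher number from compound 2 to compound 4 (0.09 log units; within the scatter) and a 1.1-fold lower number from compound 1 to compound 4 (0.05 log units; within the scatter), all lie within the scatter, so the agreement shows only that neither change moves the number measurably on these cores, not that either carries a real effect of fixed size or direction.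

On these data alone, what an amine or a carboxylic acid at that place, or a longer chain in place of methoxy, would do to the number remains open. As far as these compounds go, whether either change carries over to any other core also remains open.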